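Notes on the triazole-fused series: step to compound 4

The source may hold more compounds than are shown below. What is called first, only, known or untested is meant among the compounds shown, and "the series" means these compounds.

Measured compounds:
compound 1 `Fc1ccc(-c2noc(C3CCc4c(nnn4C4CCCC4)C3)n2)cc1` with 398 nM; 31.6 nM (2 entries)
compound 2 `CN1CCC(n2nnc3c2CCC(c2nc(-c4ccc(F)cc4)no2)C3)CC1` with 3980 nM
compound 3 `CC(C)Cc1noc(C2CCc3c(nnn3C(C)(C)C)C2)n1` with 1000 nM

In a functional assay on U2OS cells for positive allosteric modulation of metabotropic glutamate receptor 5 (Homo sapiens), read by calcium flux, in the presence of a further agent that is not named here (a higher number here means that more compound is needed for the effect, a lower number that less compound is needed), compound 3 gives the lowest of the two single numbers; compound 2 stands above it by a gap that is beyond the scatter, while compound 1 is present with two entries and no single number, see (the several entries of compound 1 in this assay, 398 nM; 31.6 nM (2 entries)). Within the data shown here, no pair in this set differs in one place only, so no measured step is available.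

Compound 4 `CN(C)c1ccc(-c2noc(C3CCc4c(nnn4C(C)(C)C)C3)n2)cc1` is the one unmeasured entry. Its change from compound 3 is 4-(dimethylamino)phenyl in place of isobutyl on an aromatic carbon of the five-membered aromatic ring with 2 nitrogen and 1 oxygen. The compounds carrying a phenyl-type group there, compound 1 and compound 2, differ from compound 3 elsewhere as well, so they give only a loose hint. The step from compound 3 to compound 4 in this assay is expected to be a moderate move toward a lower number, a 2.5-fold lower number from compound 3 to compound 4 (0.40 log units; beyond the scatter), though a result within the scatter would not surprise. Compound 4 is estimated at 400 nM, within 100 nM to 1600 nM.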

Compound 4, half-maximal effective concentration: 1000 nM
The estimate for compound 4 lay 2.5-fold (0.40 log units) below the measured number; low and high end bracket the measured number.
By their numbers in this assay, from the lowest: compounds 3 and 4 (each within the scatter of the next); then compound 2.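

Exchanging isobutyl for 4-(dimethylamino)phenyl on an aromatic carbon of the five-membered aromatic ring with 2 nitrogen and 1 oxygen gives no change at the digits printed from compound 3 to compound 4 (within the scatter) in this assay. Among these compounds, this is the first measured step at this position, and it shows that a chain without a ring and a much larger group with a six-membered aromatic ring and a hydrogen-bond acceptor can stand there with no measurable change in the number. Nothing measured on these compounds accounts for this result.

From the compounds shown here alone, whether a plain phenyl, a carboxylic acid or a longer chain at this place would also leave the number unchanged remains open. Also open, going by these compounds, is whether the same exchange would behave alike on the core of compound 1, whose two entries give no single number.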